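The compounds below may be only part of what the source reports. "The series", "measured", "known", "first", "only" and "open" are said of these compounds alone.

Measured so far in a functional assay on MCF7 cells (Homo sapiens) for cytotoxicity, read by MTT assay, with a stated time of 48 h; a lower number here means a stronger inhibitor, a higher number a weaker inhibitor:
- compound 1 `CCCCCCCCCCCCNC(=O)[C@@H](NC(=O)c1cc2ccccc2o1)[C@@H](C)O`: compound 1 gives 20900 nM
- compound 2 `CCCCCCCCCCCCCCNC(=O)[C@@H](NC(=O)c1cc2ccccc2o1)[C@@H](C)O`: compound 2 gives 23400 nM
- compound 3 `CCCCCCCCCCCCCCNC(=O)[C@@H](NC(=O)c1nccc2ccccc12)[C@@H](C)O`: compound 3 gives 22800 nM

Compound 2 sits at the upper end of these three numbers, but the steps of a 1.1-fold higher number from compound 1 to compound 2 (0.05 log units; within the scatter) and a 1.0-fold lower number from compound 2 to compound 3 (0.01 log units; within the scatter) are both within the scatter, so the three compounds are indistinguishable in this assay.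

Compound 4 `CCCCCCCCCCCCCCNC(=O)[C@@H](NS(=O)(=O)c1cccs1)[C@@H](C)O` differs from compound 2 by (thiophen-2-yl)sulfonyl in place of (1-benzofuran-2-yl)carbonyl on an amine nitrogen. Neither measured step touches this kind of change: the chain lengthening in a 1.1-fold higher number from compound 1 to compound 2 (0.05 log units; within the scatter) is remote from it, and the acyl swap in a 1.0-fold lower number from compound 2 to compound 3 (0.01 log units; within the scatter) exchanges one aromatic carbonyl for another without altering the amide link. That swap, the nearer precedent, produced nothing beyond the scatter, so for compound 4 no step beyond the scatter is expected in this assay, with wider uncertainty because the sulfonyl link itself is unprecedented in the series. Compound 4 is estimated at 24000 nM, range 9000 nM to 65000 nM, an expected step of a 1.0-fold higher number from compound 2 to compound 4 (0.01 log units; within the scatter).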

Compound 4, half-maximal inhibitory concentration: 18700 nM
For compound 4 the middle estimate is 1.3-fold (0.11 log units) above the measured one; measured number inside the range.
By their numbers in this assay, from the lowest: compounds 4, 1, 3 and 2 (each within the scatter of the next).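

In this assay the step of a 1.3-fold lower number from compound 2 to compound 4 (0.10 log units; within the scatter) comes with (thiophen-2-yl)sulfonyl in place of (1-benzofuran-2-yl)carbonyl on the amine nitrogen and stays within the scatter. This position therefore accepts a sulfonyl link and one aromatic ring in place of a carbonyl link and two, with no separation in this assay. No evidence on the cause of this result is available.

Still open, from the compounds shown here alone, is whether any group on this nitrogen moves the number beyond the scatter. An amine or a carboxylic acid on the thiophene ring would test this.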